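Aryl ether series: chloro to tert-butyl on compound 3

A few compounds are considered here, and "the series" means these few. Any claim that something is new, unique, unknown or untested is made for them only; others in the source may bear on it.

Measured compounds in an assay on isolated protein for inhibition of advanced glycosylation end product-specific receptor (Homo sapiens), read by FRET, with stated times of 30 min and 1 h, tested at 4 uM; on this read-out higher numbers stand for more inhibition at the one concentration tested (going by the name of the read-out) and lower numbers for less inhibition:
- compound 1 `CCN1CCC(Oc2ccc(-c3nc4ccc(Oc5ccc(Cl)cc5)cc4o3)cc2)CC1`: 15.3%
- compound 2 `CC(C)N1CCC(Oc2ccc(-c3nc4ccc(Oc5ccc(Cl)cc5)cc4o3)cc2)CC1`: 12.7%
- compound 3 `Clc1ccc(Oc2ccc3nc(-c4ccc(OCCCN5CCCCC5)cc4)oc3c2)cc1`: 2.2%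

Compound 3 stands lowest of the three numbers in this assay. Its nearest neighbour is compound 2, reached by a number 10.5 percentage points lower from compound 2 to compound 3 (beyond the scatter), and the furthest is compound 1, reached by a number 13.1 percentage points lower from compound 1 to compound 3 (beyond the scatter). Compound 1 and compound 2 differ only by a number 2.6 percentage points lower from compound 1 to compound 2 (within the scatter), which is within the scatter. For the measured compounds named here, every measured step so far alters the group on the oxygen of the other aromatic ring; the chloro on the phenoxy ring is kept in all three compounds.

Compound 4 `CC(C)(C)c1ccc(Oc2ccc3nc(-c4ccc(OCCCN5CCCCC5)cc4)oc3c2)cc1` is the next compound. The change from compound 3 is tert-butyl in place of chloro on an aromatic carbon. Going by the values given here, no measured step touches this part of the shared core, so none of the three steps bears on it, and there is no basis in the numbers for a step in either direction. The expectation for this assay is therefore a step within the scatter, estimated as a number 1.8 percentage points higher from compound 3 to compound 4 (within the scatter). Compound 4 is expected to give about 4%, with an estimated range from -6% to 14%.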

Compound 4, a percentage reported as inhibition, at one concentration (the size of the read-out at that concentration, not a potency): "not active" (no number reported)
Compound 4 has no reported number here, so the estimate cannot be set against anything.
By their numbers in this assay, from the lowest: compound 3; then compounds 2 and 1 (each within the scatter of the next).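

For the compounds shown here, compound 4 is reported without a number in this assay, so no step from compound 3 to compound 4 can be read. The compounds shown leave open how 4-(tert-butyl)phenoxy in place of 4-chlorophenoxy changes inhibition, in size or direction. No measured evidence bears on this result.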